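This account rests on a few compounds, and the source may have more. Where it says the series, first, only, none or still open, it means among the compounds named here.

Compound 1 `Oc1cc(-c2cccc(Cl)c2)nc2ncccc12` gives 31600 nM in a functional assay on cells (Panel ovarian (Carcinoma cell lines), Homo sapiens) for inhibition; on this read-out lower numbers stand for stronger inhibition of growth and higher numbers for weaker inhibition of growth.
Compound 2 `Cc1cnc2[nH]c(-c3cccc(F)c3)cc(=O)c2c1` gives 26900 nM in this assay.
Compound 3 `Cc1ccc2c(O)cc(-c3cccc(Cl)c3)nc2n1` gives 10500 nM in this assay.

Among these three numbers compound 1 stands highest. Its gap to compound 2 lies within the usual scatter of such measurements, so nothing can be said about their order, while compound 3 is the one furthest from it. Compound 4 `Cc1ccnc2nc(-c3cccc(Cl)c3)cc(O)c12` has not yet been measured. It differs from compound 1 in one place: methyl in place of hydrogen on an aromatic carbon. The methyl enters on an aromatic carbon of a six-membered aromatic ring with 1 nitrogen, part of a fused system of two rings, opposite the ring nitrogen. Among the compounds with values here, only one measured step bears on this change: a methyl in place of hydrogen on a different aromatic carbon of the shared core gave a 3.0-fold lower number from compound 1 to compound 3 (0.48 log units; beyond the scatter). A methyl at a different carbon need not behave the same way, so a somewhat smaller move is expected. For compound 4 a step of a 2.0-fold lower number from compound 1 to compound 4 (0.30 log units; within the scatter) is expected in this assay. The estimated value for compound 4 is 16000 nM, with a range from 6000 nM to 40000 nM.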

Compound 4, concentration for total growth inhibition: 27500 nM
Compound 4: the middle estimate sits 1.7-fold (0.24 log units) below what was measured; the range from low to high includes it.
By their numbers in this assay, from the lowest: compound 3; then compounds 2, 4 and 1 (each within the scatter of the next).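

At this carbon, opposite the ring nitrogen, putting methyl in place of hydrogen gives a 1.1-fold lower number from compound 1 to compound 4 (0.06 log units; within the scatter) in this assay, so the change leaves no readable mark on the growth read-out here. The same methyl on a different aromatic carbon of the shared core gave a 3.0-fold lower number from compound 1 to compound 3 (0.48 log units; beyond the scatter), so in these compounds the outcome of adding a methyl depends on which carbon carries it. Nothing measured here explains why the two carbons behave differently.

The compounds shown carry only hydrogen or methyl at this position, so it remains open whether a longer chain such as ethyl, an amine or a methoxy group would move the number. Going by these compounds, it also remains open whether methyl groups on both carbons together would give a step different from the one seen with the methyl in compound 3 alone.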